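Halogen-to-nitro swap on the aryl imine: cytotoxicity notes

The compounds below may be only part of what the source reports. "The series", "measured", "known", "first", "only" and "open" are said of these compounds alone.

Measured compounds in an ADME assay on HepG2 cells (Homo sapiens) for cytotoxicity, read by MTT assay, with a stated time of 72 h; a lower number here means that less compound is tolerated, a higher number that more compound is tolerated:
compound 1 `Fc1ccc(/C=N/c2sc3c(c2-c2nc4ccccc4s2)CCCC3)cc1` gives 324 ug/mL
compound 2 `Clc1ccc(/C=N/c2sc3c(c2-c2nc4ccccc4s2)CCCC3)cc1` gives 397 ug/mL
compound 3 `Clc1ccccc1/C=N/c1sc2c(c1-c1nc3ccccc3s1)CCCC2` gives 370 ug/mL

Compound 3 stands second highest of the three numbers in this assay, nearest compound 2 and furthest from compound 1, with both gaps within the scatter. Compound 4 `O=[N+]([O-])c1ccc(/C=N/c2sc3c(c2-c2nc4ccccc4s2)CCCC3)cc1` is unmeasured; it differs from compound 3 by 4-nitrophenyl in place of 2-chlorophenyl on a carbon with a double bond to nitrogen. For the measured compounds named here, the steps that bear on this aryl exchange are a 1.1-fold higher number from compound 1 to compound 3 (0.06 log units; within the scatter) and a 1.1-fold lower number from compound 2 to compound 3 (0.03 log units; within the scatter), with a 1.2-fold higher number from compound 1 to compound 2 (0.09 log units; within the scatter) for the halogen exchange alone; none lies beyond the scatter. A further aryl exchange is therefore expected to move this assay by no more than the scatter, in no definite direction. For compound 4 the estimate is 350 ug/mL, range 200 ug/mL to 600 ug/mL, which means an expected step of a 1.1-fold lower number from compound 3 to compound 4 (0.02 log units; within the scatter).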

Compound 4, half-maximal cytotoxic concentration: 454 ug/mL
Compound 4: the middle estimate sits 1.3-fold (0.11 log units) below what was measured; measured number inside the range.
By their numbers in this assay, from the lowest: compounds 1, 3, 2 and 4 (each within the scatter of the next).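

In this assay the exchange is no longer confined to halogens: with a 1.2-fold higher number from compound 3 to compound 4 (0.09 log units; within the scatter) and a 1.1-fold higher number from compound 2 to compound 4 (0.06 log units; within the scatter) and also a 1.4-fold higher number from compound 1 to compound 4 (0.15 log units; within the scatter) all within the scatter, 4-nitrophenyl on a carbon with a double bond to nitrogen cannot be told apart from the halogenated aryl groups. Entry of a group with 2 hydrogen-bond acceptors therefore gives no readable step at this position. Nothing available explains this result.

As far as these compounds go, whether an amine, a carboxylic acid or an alkyl chain in place of the aryl group would produce a step beyond the scatter remains open.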